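Adding a Bromine: Expected Cytotoxicity of Compound 4

This account rests on a few compounds, and the source may have more. Where it says the series, first, only, none or still open, it means among the compounds named here.

Of the compounds shown here, three have so far been measured in a functional assay on PC-3 cells (Homo sapiens) for cytotoxicity, read by sulforhodamine B assay, with a stated time of 48 h; on this read-out lower numbers stand for stronger inhibition and higher numbers for weaker inhibition. Compound 1 `CC(=O)N1N=C(c2ccc(Br)cc2)CC1c1cccc(Cl)c1Cl` gives 38800 nM, compound 2 `COc1cc(C2CC(c3cccc4ccccc34)=NN2C(C)=O)cc(OC)c1OC` gives 1090 nM, and compound 3 `O=CCN1N=C(c2ccc3ccccc3c2)CC1c1ccccc1` gives 7400 nM. Compound 3 therefore holds the second-highest number of the three: compound 1 stands nearer to it and compound 2 furthest, both gaps lying beyond the usual scatter of this assay. Compound 4 `O=CCN1N=C(c2ccc3ccccc3c2)CC1c1cccc(Br)c1` differs from compound 3 in one place only: bromo in place of hydrogen on an aromatic carbon. Among the compounds with values here, no measured pair shows what this change does, so the expectation rests on the change itself. A small step, perhaps toward a lower number and hardly beyond the scatter, is expected, a 1.5-fold lower number from compound 3 to compound 4 (0.17 log units; within the scatter). Compound 4 is thus estimated at 5000 nM, within 2000 nM to 15000 nM.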

Compound 4, half-maximal inhibitory concentration: 10900 nM
Compound 4: middle estimate off by 2.2-fold (0.34 log units), on the low side; the range from low to high includes it.
By their numbers in this assay, from the lowest: compound 2; then compounds 3 and 4 (each within the scatter of the next); then compound 1.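

In this assay, bromo in place of hydrogen on this aromatic carbon, meta to a large group, gives a 1.5-fold higher number from compound 3 to compound 4 (0.17 log units; within the scatter) and so stays within the scatter. Within the data shown here, this position therefore takes a bromine without a readable change in the number, something the earlier compounds could not show, as no measured pair among them isolated this change. From the compounds shown here alone, whether an amine or a carboxylic acid on the same carbon would move the number beyond the scatter remains open. Nothing given here offers a reason for this small step.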